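The source may hold more compounds than are shown below. What is called first, only, known or untested is meant among the compounds shown, and "the series" means these compounds.

Working notes on the series. Two members of the set have numbers in an assay on cells for inhibition of Amine oxidase [flavin-containing] B (Homo sapiens), read by Amplex Red, with a stated time of 30 min; a higher number here means a weaker inhibitor, a lower number a stronger inhibitor. Compound 1 `O=C1COC(c2ccc(/C=C/c3ccccc3)cc2)=NN1` gives 165 nM. Compound 2 `O=C1COC(c2ccc(/C=C/c3ccc(Cl)cc3)cc2)=NN1` gives 542 nM. For the measured compounds named here, the one measured step, a 3.3-fold higher number from compound 1 to compound 2 (0.52 log units; beyond the scatter), is the only movement recorded so far, and it leaves compound 2 standing at the highest of the two numbers, with compound 1 the nearest comparator. Compound 3 `Cc1cccc(/C=C/c2ccc(C3=NNC(=O)CO3)cc2)c1` has not yet been measured in this assay. It differs from compound 2 by 3-methylphenyl in place of 4-chlorophenyl on a double-bonded chain carbon bound to a double-bonded chain carbon. Going by the values given here, the step from compound 1 to compound 2 bears on this change only in part: it shows what a chloro substituent does relative to the unsubstituted phenyl, whereas the 3-methylphenyl of compound 3 carries a substituent of another kind in another place, for which no step exists in the set. Among the compounds with values here, removing the chloro should, on the strength of the single recorded step, bring the number back toward compound 1, and the methyl is assumed to add little beyond the scatter. Compound 3 is therefore expected at 250 nM, with a range from 80 nM to 800 nM. Against compound 2 this estimate means a 2.2-fold lower number from compound 2 to compound 3 (0.34 log units; beyond the scatter).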

Compound 3, half-maximal inhibitory concentration: 338 nM
Compound 3: middle estimate off by 1.4-fold (0.13 log units), on the low side, within the range that was stated.
By their numbers in this assay, from the lowest: compound 1; then compounds 3 and 2 (each within the scatter of the next).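

In this assay, the 3-methylphenyl in place of 4-chlorophenyl on a double-bonded chain carbon bound to a double-bonded chain carbon gives [ a 1.6-fold lower number from compound 2 to compound 3 (0.21 log units; within the scatter) ], so this exchange of one substituted phenyl for another leaves no resolved difference between the two compounds. Adding a methyl to the unsubstituted phenyl gives [ a 2.0-fold higher number from compound 1 to compound 3 (0.31 log units; beyond the scatter) ], which shows that a substituent other than chloro also carries a modest step away from the unsubstituted phenyl; among these three compounds, both substituted members have higher numbers than compound 1, and none goes against that pattern. No measurement available here accounts for these steps.

The exchange between compound 2 and compound 3 alters both the group and the aromatic carbon that carries it, so the compounds shown do not separate the contribution of substituent kind from that of its place on the ring. Going by these compounds, it also remains open whether the same upward step would hold if a methoxy, an amine or a carboxylic acid were put on the phenyl instead of the methyl.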